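Carbamate series: aryl change at the carbamate carbon

The source may report more compounds than this note shows. Statements on the series, on what has been measured and on what is new or still open speak of the compounds shown alone.

Compound 1 `NC(=O)OC(CCN1CCN(c2ccccc2)CC1)c1cccc(Cl)c1` and compound 2 `COc1ccc(N2CCN(CCC(OC(N)=O)c3ccc(Cl)c(Cl)c3)CC2)cc1` share the carbamate core. In a functional assay on the whole organism for inhibition, with Mus musculus as the target, in the writhing test, with a stated time of 1 h, at a dose of 10 mg/kg by the oral route (on this read-out lower numbers stand for less inhibition and higher numbers for more inhibition at the one dose given (going by the name of the read-out)), compound 1 gives 59%, while compound 2 gives 61%, a gap within the usual scatter, so neither can be ranked against the other. Compound 3 `NC(=O)OC(CCN1CCN(c2ccccc2)CC1)c1ccc([N+](=O)[O-])cc1` is not yet measured; it differs from compound 1 in one place: 4-nitrophenyl in place of 3-chlorophenyl on a saturated chain carbon bound to an oxygen next to a carbonyl group and a saturated chain carbon. Within the data shown here, no comparable step between measured compounds exists, so no direction is supported. Compound 3 is expected to give 55%, in the range 35% to 75%. The expected step of a number 4 percentage points lower from compound 1 to compound 3 (within the scatter) is estimated to fall within the scatter.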

Compound 3, a percentage reported as inhibition, in the whole organism at one dose (the size of the read-out at that dose, not a potency): 91.2%
Compound 3: middle estimate off by 36.2 percentage points, on the low side; the measured number lies above the stated range.
By their numbers in this assay, from the lowest: compounds 1 and 2 (each within the scatter of the next); then compound 3.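

In this assay, the saturated chain carbon bound to an oxygen next to a carbonyl group and a saturated chain carbon proves sensitive to its aryl group: 4-nitrophenyl in place of 3-chlorophenyl gives a number 32.2 percentage points higher from compound 1 to compound 3 (beyond the scatter). Among these compounds, this is the first step that can be read at this position, and it is a large one. No measurement at hand bears on what lies behind it.

Among the compounds shown here, the single step changes both the group on the ring and where it sits, so the two cannot be separated. From the compounds shown here alone, whether an amine or a nitrile on that ring would give a similar number remains open.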